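Methoxy to ethoxy on an inactive diaryl aminopyrimidine-type core

This account rests on a few compounds, and the source may have more. Where it says the series, first, only, none or still open, it means among the compounds named here.

Compound 1 `C#CCOc1ccc(-c2cc(-c3ccc(OCC#C)c(OC)c3)nc(N)n2)cc1` carries a methoxy on one of its two aryl rings, both of which bear a propargyloxy chain. In an assay on BTI-TN-5B1-4 cells for inhibition of Amine oxidase [flavin-containing] A (Homo sapiens), read by fluorescence and Amplex Red, using microsomes, with a stated time of 30 min (a higher number here means a weaker inhibitor, a lower number a stronger inhibitor), compound 1 gives "not active" (no number reported), so no number stands for it and no position on the scale can be assigned; it sits outside the range in which the two analogs without the methoxy were read. Compound 2 `C#CCOc1ccc(-c2cc(-c3ccccc3OCC#C)nc(N)n2)cc1` gives 28600 nM in this assay. Compound 3 `C#CCOc1ccc(-c2cc(-c3cccc(OCC#C)c3)nc(N)n2)cc1` gives 24100 nM in this assay. The values of compound 2 and compound 3 lie within the usual scatter of each other, and both are weak.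

Compound 4 `C#CCOc1ccc(-c2cc(-c3ccc(OCC#C)c(OCC)c3)nc(N)n2)cc1` differs from compound 1 by methyl in place of hydrogen on a saturated chain carbon bound to an oxygen on an aromatic ring. Going by the values given here, nothing measured speaks to this difference, and compound 1 itself contributes no number, so no step can be computed. The starting point is an inactive compound and its two closest measured relatives are weak; the expectation is therefore a weak or unreported result, with no step beyond the scatter that could be named in either direction. Compound 4 is estimated at 40000 nM, within a range from 12000 nM to 150000 nM, with a substantial chance that only a limit is reported.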

Compound 4, half-maximal inhibitory concentration: "not active" (no number reported)
Nothing numeric was reported for compound 4, so the estimate cannot be set against anything.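

In this assay compound 1 gives "not active" (no number reported) and compound 4 gives "not active" (no number reported) so no step can be read for the change from methoxy to ethoxy. No measured evidence bears on this result. The compounds shown leave open whether any other chain in that place on the core of compound 1 would give a number in this assay.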